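A few compounds are considered here, and "the series" means these few. Any claim that something is new, unique, unknown or untested is made for them only; others in the source may bear on it.

Compound 1 `COc1ccc2[nH]c3c(c2c1)CCNC31CCN(Cc2ccc(Br)c(F)c2)CC1`: 1800 nM
Compound 2 `COc1ccc2[nH]c3c(c2c1)CCNC31CCN(Cc2ccc(Br)cc2F)CC1`: 1600 nM

In an assay on FRT cells for positive allosteric modulation of Cystic fibrosis transmembrane conductance regulator variant N1303K (Homo sapiens), in the presence of a further agent that is not named here (on this read-out higher numbers stand for an effect only at larger amounts of compound and lower numbers for an effect already at smaller amounts), compound 1 gives 1800 nM, the highest of the two numbers shown. Compound 2 gives 1600 nM. The step of a 1.1-fold lower number from compound 1 to compound 2 (0.05 log units; within the scatter) lies within the scatter.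

Compound 3 `COc1ccc2[nH]c3c(c2c1)CCNC31CCN(C(C)c2ccccc2)CC1` differs from compound 1 by 1-phenylethyl in place of 4-bromo-3-fluorobenzyl on an amine nitrogen in a ring. Among the measured compounds shown here, no measured step covers a change of this kind: the only step, a 1.1-fold lower number from compound 1 to compound 2 (0.05 log units; within the scatter), concerns a different exchange and lies within the scatter, so it offers no guide. A modest step toward a higher number is expected, a 1.7-fold higher number from compound 1 to compound 3 (0.22 log units; within the scatter), with wide uncertainty. Compound 3 is therefore estimated at 3000 nM, with a range from 900 nM to 10000 nM.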

Compound 3, half-maximal effective concentration: 20000 nM
Compound 3: the middle estimate sits 6.7-fold (0.82 log units) below what was measured; the measured number lies above the stated range.
By their numbers in this assay, from the lowest: compounds 2 and 1 (each within the scatter of the next); then compound 3.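

The group on the ring amine nitrogen matters far more than the earlier fluorine shift suggested: moving to 1-phenylethyl means more compound is needed for the effect (an 11-fold higher number from compound 1 to compound 3 (1.05 log units; beyond the scatter) and a 13-fold higher number from compound 2 to compound 3 (1.10 log units; beyond the scatter)). This single exchange removes the bromine and the fluorine and also brings in a branched chain carbon, so the steps cannot be assigned to any one of these. Nothing available here explains them.

From the compounds shown here alone, it remains open which of these features counts most. Plain benzyl, 4-bromobenzyl or 1-(4-bromophenyl)ethyl on the same nitrogen would help separate them.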